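Nitrate ester cinnamates: effect of methylating the ring hydroxyl

The compounds below may be only part of what the source reports. "The series", "measured", "known", "first", "only" and "open" are said of these compounds alone.

Measured compounds and their values in a functional assay on SKBR cells (Homo sapiens) for cytotoxicity, read by resazurin assay, with a stated time of 72 h; on this read-out lower numbers stand for stronger inhibition and higher numbers for weaker inhibition:
compound 1 `O=C(/C=C/c1ccc(OCCCCCO[N+](=O)[O-])c(O)c1)OCCCCCO[N+](=O)[O-]` gives 2710 nM.
compound 2 `O=C(/C=C/c1ccc(OCCCCCCO[N+](=O)[O-])c(O)c1)OCCCCCCO[N+](=O)[O-]` gives 39700 nM.
compound 3 `COc1cc(/C=C/C(=O)OCCCCCO[N+](=O)[O-])ccc1OCCCCCO[N+](=O)[O-]` gives only a limit, > 50000 nM.

Compound 1 and compound 2 differ in the chains carrying the nitrate esters; the difference between the two cores is not broken down here. Of the two numbers, compound 2 stands highest, with compound 1 below it by a gap beyond the scatter.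

The change methyl in place of hydrogen on an oxygen on an aromatic ring produces an at least 18-fold higher number from compound 1 to compound 3 (1.26 log units; beyond the scatter). On these data alone, the value of compound 3 is a limit, (the limit of > 50000 nM in this assay, at which 1 of the 3 values shown sits), so the true size of that step is unknown beyond its lower bound.

Compound 4 `COc1cc(/C=C/C(=O)OCCCCCCO[N+](=O)[O-])ccc1OCCCCCCO[N+](=O)[O-]` carries the same change against compound 2: methyl in place of hydrogen on an oxygen on an aromatic ring. The place of the change reads the same in both pairs, so this is the same kind of change on a different core.

Among the measured compounds shown here, since the only measured instance of this change gave an at least 18-fold higher number from compound 1 to compound 3 (1.26 log units; beyond the scatter) and compound 2 already starts high, compound 4 is expected to move by a 3.8-fold higher number from compound 2 to compound 4 (0.58 log units; beyond the scatter). Compound 4 is estimated at 150000 nM, between 40000 nM and 600000 nM, and will most probably be reported only as a limit in this assay.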

Compound 4, half-maximal inhibitory concentration: > 50000 nM
Compound 4 ended at the assay's limit; the forecaster's own chance of this, stated with the estimate: 85%; the middle value lies beyond the limit too.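

In this assay compound 4 gives > 50000 nM, which is a limit and not a number. Hydroxy to methoxy on the second core gives an at least 1.2-fold higher number from compound 2 to compound 4 (0.10 log units; that floor lies within the scatter), so the result does not go against the large step on the first core, but it does not confirm that step either. Read together, the two pairs show only that neither methoxy compound gives a measured number, not that the change carries over with the same size: the same change on two cores in this assay, an at least 18-fold higher number (1.26 log units; beyond the scatter) from compound 1 to compound 3 and an at least 1.2-fold higher number (0.10 log units; that floor lies within the scatter) from compound 2 to compound 4; the limit leaves it open whether they differ.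

Both methoxy compounds rest on one ceiling, so neither step has a known upper end: the limit of > 50000 nM in this assay, at which 2 of the 4 values shown sit. On these data alone, it also remains open whether ethoxy, an amine or a carboxylic acid in place of the hydroxy would fare like methoxy, and how a shorter or longer chain carrying the nitrate ester would read with the free hydroxy kept.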